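Alkoxy chain extension: expected effect of one more carbon

The source may report more compounds than this note shows. Statements on the series, on what has been measured and on what is new or still open speak of the compounds shown alone.

Going by the values given here, compound 2 (`CCCCCOc1ccc2nncn2n1`) holds the only number so far in a functional assay on the whole organism with Mus musculus as the target (on this read-out lower numbers stand for an effect already at smaller amounts and higher numbers for an effect only at larger amounts of compound), where compound 2 gives 39.4 mg/kg. Compound 1 (`CCCCOc1ccc2nncn2n1`) gives only a limit of the assay in this assay: for compound 1 the value reads > 100 mg/kg. Among the compounds with values here, the one measured step, an at least 2.5-fold lower number from compound 1 to compound 2 (0.40 log units; beyond the scatter), rests on (the limit of > 100 mg/kg in this assay, at which 1 of the 2 values shown sits). Compound 3 (`CCCCCCOc1ccc2nncn2n1`) is not yet measured; it differs from compound 2 by methyl in place of hydrogen on a saturated chain carbon, five bonds along the chain from an oxygen on an aromatic ring. This is the same kind of change as the measured step, cut one bond further out along the chain. That step is the only one that bears on it: an at least 2.5-fold lower number from compound 1 to compound 2 (0.40 log units; beyond the scatter). A further lowering of the number is therefore expected, though a single step gives no guarantee that it repeats at the next chain length, and the size of that step is itself open-ended. For compound 3 the estimated step is a 1.6-fold lower number from compound 2 to compound 3 (0.20 log units; within the scatter). Compound 3 is expected to give 25 mg/kg, within 8 mg/kg to 80 mg/kg.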

Compound 3, dose for half-maximal effect: 32.9 mg/kg
Estimate against measurement, compound 3: 1.3-fold (0.12 log units) below; the measured number falls inside the stated range.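

In this assay, methyl in place of hydrogen on a saturated chain carbon, five bonds along the chain from an oxygen on an aromatic ring, gives a 1.2-fold lower number from compound 2 to compound 3 (0.08 log units; within the scatter), so compound 2 and compound 3 cannot be told apart on this read-out. Going by these compounds alone, the same kind of change four bonds along the chain gave an at least 2.5-fold lower number from compound 1 to compound 2 (0.40 log units; beyond the scatter), which lies beyond the scatter, so the series now shows that a further carbon at the end of the chain need not bring a readable change, and the only steps beyond the scatter are those that start from compound 1, including an at least 3.0-fold lower number from compound 1 to compound 3 (0.48 log units; beyond the scatter). Those steps have no fixed size, as they rest on a limit of the assay and not on a number: the limit of > 100 mg/kg in this assay, at which 1 of the 3 values shown sits.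

The compounds shown leave open whether a longer chain would give a number that differs from those of compound 2 and compound 3 beyond the scatter, or whether the trend stops at this length. They also leave open what a polar group such as an amine or a carboxylic acid at the end of the chain would do in this assay.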